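From a Pyrrole Ketone to a Phenol Ketone

The compounds below may be only part of what the source reports. "The series", "measured", "known", "first", "only" and "open" are said of these compounds alone.

Compound 1, `Cn1cccc1C(=O)/C=C/c1ccc2c(c1)B(O)OC2`, carries a 1-methyl-1H-pyrrol-2-yl group on the carbonyl carbon of the shared core. In a functional assay on HCT-116 cells (Homo sapiens) for cytotoxicity, read by MTT assay, with a stated time of 48 h (on this read-out higher numbers stand for weaker inhibition and lower numbers for stronger inhibition), compound 1 gives only a limit, > 100000 nM, so no number is known for it. Compound 1 therefore sits at the limit of > 100000 nM in this assay, at which 1 of the 3 values shown sits. Two related compounds do give numbers: compound 2, `O=C(/C=C/c1ccc2c(c1)B(O)OC2)c1ccc(C(F)(F)F)cc1`, gives 6300 nM in this assay, and compound 3, `O=C(/C=C/c1ccc2c(c1)B(O)OC2)c1ccc(Cl)c(Cl)c1`, gives 3200 nM in this assay. Within the data shown here, no measured step between any pair of these three is given, so only their bare values stand side by side.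

Compound 4, `O=C(/C=C/c1ccc2c(c1)B(O)OC2)c1cccc(O)c1`, differs from compound 1 in one place: 3-hydroxyphenyl in place of 1-methyl-1H-pyrrol-2-yl on a carbonyl carbon. Because compound 2 gives 6300 nM and compound 3 gives 3200 nM, a real number rather than a limit is expected for compound 4, and a step of an at least 6.6-fold lower number from compound 1 to compound 4 (0.82 log units; beyond the scatter) toward stronger inhibition is expected in this assay. Compound 4 is estimated at 15000 nM in this assay, within a range from 4000 nM to 60000 nM.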

Compound 4, half-maximal inhibitory concentration: 6500 nM
Estimate against measurement, compound 4: 2.3-fold (0.36 log units) above; the range from low to high includes it.
By their numbers in this assay, from the lowest: compounds 3, 2 and 4 (each within the scatter of the next, the first and the last beyond it). At a limit, above all of these: compound 1.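

Among these compounds, this pair gives the first step in the set that can be read across a single change: in this assay, the swap of 1-methyl-1H-pyrrol-2-yl for 3-hydroxyphenyl on the carbonyl carbon gives an at least 15-fold lower number from compound 1 to compound 4 (1.18 log units; beyond the scatter). The group at this place can therefore decide whether the read-out yields a real number or only a limit. On these data alone, compound 1 has only a limit, so the step gives a minimum and its full size stays unknown: the limit of > 100000 nM in this assay, at which 1 of the 4 values shown sits.

The step cannot separate the effect of changing the ring from the effect of adding the hydroxyl, as the two changes arrive together. As far as these compounds go, how a plain phenyl group, or a phenyl ring carrying an amine or a carboxylic acid in place of the hydroxyl, would read at this place stays open.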